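The compounds below may be only part of what the source reports. "The series", "measured", "known", "first", "only" and "open" are said of these compounds alone.

Measured so far in a functional assay on HeLa cells (Homo sapiens) for cytotoxicity, read by ELISA, with a stated time of 2 days (on this read-out higher numbers stand for weaker inhibition and lower numbers for stronger inhibition), are three compounds
- compound 1 `Oc1cccc(-c2cc(-c3ccccc3)nc(-c3cccs3)c2)c1` gives 15300 nM here
- compound 2 `Oc1cccc(-c2cc(-c3ccccc3)nc(-c3ccccn3)c2)c1` gives 29800 nM here
- compound 3 `Oc1cccc(-c2cc(-c3ccccc3)nc(-c3cccnc3)c2)c1` gives 17500 nM here

Compound 3 at 17500 nM cannot be separated from the other two, with a 1.1-fold higher number from compound 1 to compound 3 (0.06 log units; within the scatter) and a 1.7-fold lower number from compound 2 to compound 3 (0.23 log units; within the scatter) on record. Compound 4 `Oc1cccc(-c2cc(-c3ccccc3)nc(-c3ccncc3)c2)c1` carries pyridin-4-yl in place of pyridin-3-yl on an aromatic carbon and is otherwise the same as compound 3. The closest measured precedent is a 1.7-fold lower number from compound 2 to compound 3 (0.23 log units; within the scatter) for pyridin-3-yl in place of pyridin-2-yl. The exchange of thiophen-2-yl for pyridin-2-yl, a 1.9-fold higher number from compound 1 to compound 2 (0.29 log units; within the scatter) in size, also stays small. On this evidence, no step beyond the scatter is expected in this assay for the new exchange. The expected shift is a 1.1-fold higher number from compound 3 to compound 4 (0.06 log units; within the scatter) and no more. Compound 4 is estimated at 20000 nM in this read-out, with an expected range from 11000 nM to 36000 nM across repeat measurements.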

Compound 4, half-maximal inhibitory concentration: 15000 nM
Beside the measured number, compound 4's estimate is 1.3-fold (0.12 log units) above it, and the stated range covers the measured number.
By their numbers in this assay, from the lowest: compounds 4, 1, 3 and 2 (each within the scatter of the next).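

With pyridin-4-yl at this place, all three pyridinyl attachments can be compared in this assay, and none separates from another: pyridin-4-yl in place of pyridin-3-yl gives a small step (a 1.2-fold lower number from compound 3 to compound 4 (0.07 log units; within the scatter)), and even the widest pyridine exchange, pyridin-4-yl in place of pyridin-2-yl, stays inside the scatter (a 2.0-fold lower number from compound 2 to compound 4 (0.30 log units; within the scatter)). The exchange of thiophen-2-yl for pyridin-4-yl adds a further small step (a 1.0-fold lower number from compound 1 to compound 4 (0.01 log units; within the scatter)), so among these four compounds neither the attachment point of the pyridine nor the swap from thiophene to pyridine registers beyond the scatter. Nothing available explains this flat result.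

As far as these compounds go, it remains open whether an amine, a carboxylic acid or a longer alkyl chain at this place would give a step beyond the scatter. The four compounds also leave open how the number responds to changes in the 3-hydroxyphenyl group, such as a methoxy group in place of the hydroxyl.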